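Working notes: cytotoxicity series, compound 3 to compound 4

The source may hold more compounds than are shown below. What is called first, only, known or untested is meant among the compounds shown, and "the series" means these compounds.

The three measured compounds share one core and differ only in the substituent on the amine nitrogen. Compound 1 `Cc1cn([C@@H]2O[C@H](CO[Si](C)(C)C(C)(C)C)[C@@]3(OS(=O)(=O)C=C3NCCC(N)=O)[C@H]2O[Si](C)(C)C(C)(C)C)c(=O)n(C)c1=O` gives 20000 nM in a functional assay on MT4 cells (Homo sapiens); on this read-out lower numbers stand for higher toxicity in this test and higher numbers for lower toxicity in this test. Compound 2 `CCOC(=O)CNC(=O)NC1=CS(=O)(=O)O[C@@]12[C@@H](CO[Si](C)(C)C(C)(C)C)O[C@@H](n1cc(C)c(=O)n(C)c1=O)[C@@H]2O[Si](C)(C)C(C)(C)C` gives 3780 nM in this assay, a step of a 5.3-fold lower number from compound 1 to compound 2 (0.72 log units; beyond the scatter). Compound 3 `C=C(C)C(=O)NC(=O)NC1=CS(=O)(=O)O[C@@]12[C@@H](CO[Si](C)(C)C(C)(C)C)O[C@@H](n1cc(C)c(=O)n(C)c1=O)[C@@H]2O[Si](C)(C)C(C)(C)C` gives 1190 nM in this assay, the lowest of the three numbers, with steps of a 17-fold lower number from compound 1 to compound 3 (1.23 log units; beyond the scatter) and a 3.2-fold lower number from compound 2 to compound 3 (0.50 log units; beyond the scatter).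

Compound 4 `Cc1cn([C@@H]2O[C@H](CO[Si](C)(C)C(C)(C)C)[C@@]3(OS(=O)(=O)C=C3NCC(=O)O)[C@H]2O[Si](C)(C)C(C)(C)C)c(=O)n(C)c1=O` is not yet measured; the change from compound 3 is carboxymethyl in place of ((1-methylethenyl)carbonyl)carbamoyl on an amine nitrogen. Within the data shown here, the steps that bear on it run the other way: every move from the larger acyl-carbamoyl group toward a shorter polar tail in compound 1 and compound 2 raised the number, and carboxymethyl is closest in kind to the tail of compound 1 and the ester of compound 2. A rise is therefore expected, roughly of the size seen from compound 3 back toward compound 1 and compound 2, as an 8.4-fold higher number from compound 3 to compound 4 (0.92 log units; beyond the scatter). Compound 4 is estimated at 10000 nM in this assay, within 2500 nM to 40000 nM.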

Compound 4, half-maximal cytotoxic concentration: 30000 nM
For compound 4 the middle estimate is 3.0-fold (0.48 log units) below the measured one, within the range that was stated.
By their numbers in this assay, from the lowest: compound 3; then compound 2; then compounds 1 and 4 (each within the scatter of the next).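

In this assay, carboxymethyl on this amine nitrogen reverses the fall in the number seen with the carbamoyl-linked groups, with a 25-fold higher number from compound 3 to compound 4 (1.40 log units; beyond the scatter) and a 7.9-fold higher number from compound 2 to compound 4 (0.90 log units; beyond the scatter). Carboxy in place of carbamoylmethyl on the saturated chain gives a 1.5-fold higher number from compound 1 to compound 4 (0.18 log units; within the scatter), so the end of the chain can change here without a readable shift, and among these four compounds the two lower numbers belong to compound 2 and compound 3, whose substituents are joined to the amine nitrogen through a carbamoyl group, with no compound going against this. No measurement available here accounts for this difference.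

Still open, from the compounds shown here alone, is whether the carbamoyl link or the group beyond it goes with the lower numbers. An ethoxycarbonylmethyl or a plain acetyl group directly on the amine nitrogen would help separate the two.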